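Moving the fluorine from 4-fluorobenzyl to 3-fluorobenzyl

The source may report more compounds than this note shows. Statements on the series, on what has been measured and on what is new or still open speak of the compounds shown alone.

In a functional assay on GBM1 cells (Homo sapiens) for antiproliferative activity, read by WST assay, with a stated time of 72 h (on this read-out lower numbers stand for stronger inhibition and higher numbers for weaker inhibition), compound 2 (`O=C(Nc1cc2ncncc2cc1OCc1ccc(F)cc1)Nc1cccc2ccccc12`) gives 8100 nM and compound 1 (`O=C(Nc1cc2ncncc2cc1OCc1ccc(Cl)cc1)Nc1cccc2ccccc12`) gives 7900 nM at the high end of the three numbers, while compound 3 (`O=C(Nc1cccc(Cl)c1)Nc1cc2ncncc2cc1OCc1cccc(Cl)c1`) gives 3300 nM on a lower number beyond the scatter. Compound 4 (`O=C(Nc1cc2ncncc2cc1OCc1cccc(F)c1)Nc1cccc2ccccc12`) differs from compound 2 by 3-fluorophenyl in place of 4-fluorophenyl on a saturated chain carbon bound to an oxygen on an aromatic ring in one place, 4-fluorobenzyl to 3-fluorobenzyl. For the measured compounds named here, the only measured single-place step, a 1.0-fold higher number from compound 1 to compound 2 (0.01 log units; within the scatter) for fluoro in place of chloro, lies within the scatter and does not test this shift. Compound 3 differs from compound 2 in more than one place and offers only a faint hint. The expected step, a 1.2-fold lower number from compound 2 to compound 4 (0.10 log units; within the scatter) in size, stays within the scatter. In this assay compound 4 is expected at 6500 nM and between 3000 nM and 13000 nM in most repeats.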

Compound 4, half-maximal inhibitory concentration: 1300 nM
Beside the measured number, compound 4's estimate is 5.0-fold (0.70 log units) above it, outside the stated range (below it).
By their numbers in this assay, from the lowest: compound 4; then compound 3; then compounds 1 and 2 (each within the scatter of the next).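

In this assay the position of the fluorine on the benzyl group proves to matter: 3-fluorophenyl in place of 4-fluorophenyl gives a 6.2-fold lower number from compound 2 to compound 4 (0.79 log units; beyond the scatter), whereas swapping the halogen alone gave a 1.0-fold higher number from compound 1 to compound 2 (0.01 log units; within the scatter). The change from 4-chlorophenyl gives a 6.1-fold lower number from compound 1 to compound 4 (0.78 log units; beyond the scatter), so compound 4 stands clear of both earlier compounds that differ from it in one place. Nothing available here explains why this shift lowers the number.

The compounds shown leave open whether 3-chlorobenzyl, 3-methoxybenzyl or plain benzyl on the core of compound 4 would match 3-fluorobenzyl.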